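From Acetyl to 3,4-Dimethoxyphenyl: A Cytotoxicity Expectation

A few compounds are considered here, and "the series" means these few. Any claim that something is new, unique, unknown or untested is made for them only; others in the source may bear on it.

Of the compounds shown here, two have so far been measured in a functional assay on PC-12 cells (Rattus norvegicus) for cytotoxicity, read by MTT assay, with stated times of 3 h and 2 h, tested at 10 uM; a lower number here means a weaker effect, a higher number a stronger effect of the compound at the concentration tested. Compound 1 `O=C(CCCCC1CCSS1)NCc1cn(CCCOc2ccc3ccc(=O)oc3c2)nn1` gives 40%. Compound 2 `CC(=O)c1cc2ccc(OCCCCCn3cc(CNC(=O)CCCCC4CCSS4)nn3)cc2oc1=O` gives 20.8%, the lower of the two numbers; its gap to compound 1 lies beyond the usual scatter. Compound 3 `COc1ccc(-c2cc3ccc(OCCCCCn4cc(CNC(=O)CCCCC5CCSS5)nn4)cc3oc2=O)cc1OC` has not yet been measured. It differs from compound 2 in a single place: 3,4-dimethoxyphenyl in place of acetyl on an aromatic carbon. Among the compounds with values here, no step between measured compounds isolates this kind of change, so there is no precedent within the set on which a direction could be grounded. The account therefore expects the step of a number 6.2 percentage points higher from compound 2 to compound 3 (within the scatter) to be small and upward, but not clearly beyond the scatter. On that basis the value expected for compound 3 in this assay is 27%, with a range from 10% to 48%.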

Compound 3, a percentage reported as activity, at one concentration (the size of the read-out at that concentration, not a potency): 50.5%
The estimate for compound 3 lay 23.5 percentage points below the measured number; the measured number lies above the stated range.
By their numbers in this assay, from the lowest: compound 2; then compound 1; then compound 3.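

In this assay, within the data shown here, the exchange of acetyl for 3,4-dimethoxyphenyl on this aromatic carbon, two atoms from the ring oxygen, gives a number 29.7 percentage points higher from compound 2 to compound 3 (beyond the scatter) and is the first change in the set to be isolated at this position. It shows that the read-out at the tested concentration depends on the group at this position, and that the effect rises when an aromatic ring of carbon only enters in place of the acetyl group. No measurement shown here accounts for this step.

On these data alone, it remains open whether the step belongs to the aromatic ring itself or to its two methoxy groups, which an unsubstituted phenyl on the same carbon could help to separate. As far as these compounds go, whether an amine or a carboxylic acid at this position would move the number in the same direction also remains open.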